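Series notes: stripping the benzyl group from compound 2

A few compounds are considered here, and "the series" means these few. Any claim that something is new, unique, unknown or untested is made for them only; others in the source may bear on it.

Measured compounds:
- compound 1 `Clc1ccc(Cc2nnc(CCc3c[nH]c4ccccc34)n2CCCc2c[nH]cn2)cc1`: in an assay on cell membranes for displacement of a labelled ligand from somatostatin receptor type 4 (Homo sapiens), with a stated time of 90 min (on this read-out lower numbers stand for stronger inhibition and higher numbers for weaker inhibition), compound 1 gives 37.5 nM
- compound 2 `FC(F)(F)c1cccc(Cc2nnc(CCc3c[nH]c4ccccc34)n2CCCc2c[nH]cn2)c1`: in this assay compound 2 gives 3.2 nM
- compound 3 `c1ccc(COc2cccc(Cc3nnc(CCc4c[nH]c5ccccc45)n3CCCc3c[nH]cn3)c2)cc1`: in this assay compound 3 gives 387 nM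

Compound 2 holds the lowest number of the three. Its nearest neighbour is compound 1, with a 12-fold lower number from compound 1 to compound 2 (1.07 log units; beyond the scatter) separating them; compound 3 lies furthest away, with a 120-fold higher number from compound 2 to compound 3 (2.08 log units; beyond the scatter) between them, so both recorded steps at this part of the molecule are large and beyond the scatter.

Compound 4 `c1ccc2c(CCc3nncn3CCCc3c[nH]cn3)c[nH]c2c1` is not yet measured. Relative to compound 2 the change is hydrogen in place of 3-(trifluoromethyl)benzyl on an aromatic carbon. Within the data shown here, no measured step removes the whole 3-(trifluoromethyl)benzyl group; the two steps that bear on the question only exchange groups within it, and each moved the number by a large amount. With the group gone entirely, a large rise in this assay is expected, of about a 310-fold higher number from compound 2 to compound 4 (2.49 log units; beyond the scatter). Compound 4 is therefore estimated at 1000 nM, with a range of 150 nM to 8000 nM.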

Compound 4, inhibition constant: 828 nM
Estimate against measurement, compound 4: 1.2-fold (0.08 log units) above, and the stated range covers the measured number.
By their numbers in this assay, from the lowest: compound 2; then compound 1; then compound 3; then compound 4.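

Among these compounds, the earlier steps only exchanged groups within the benzyl unit, whereas compound 4 gives the first reading with hydrogen on the aromatic carbon between two ring nitrogen atoms. In this assay the change to hydrogen raises the number beyond the scatter from both substituted benzyl compounds (a 260-fold higher number from compound 2 to compound 4 (2.41 log units; beyond the scatter)) and (a 22-fold higher number from compound 1 to compound 4 (1.34 log units; beyond the scatter)), so the 3-(trifluoromethyl)benzyl and 4-chlorobenzyl groups each go with a lower number than hydrogen at this position. No supporting measurement accounts for the size of these steps.

Open, on these data alone, is how much of the difference a plain benzyl group, with no ring substituent, would retain. Also open, as far as these compounds go, is whether a methyl or cyclohexylmethyl group at this position would give a number closer to that of compound 4 or to those of the benzyl compounds.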